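Extending the Alkyl Chain on the Core, One Carbon at a Time

The compounds below may be only part of what the source reports. "The series", "measured", "known", "first", "only" and "open" are said of these compounds alone.

Measured compounds:
Compound 1, `CCc1nc2cccc(C(=O)O)c2n1Cc1ccc(-c2ccccc2-c2noc(O)n2)cc1`: 88%
Compound 2, `CCCc1nc2cccc(C(=O)O)c2n1Cc1ccc(-c2ccccc2-c2noc(O)n2)cc1`: 100%

Among the compounds with values here, compound 2 gives the higher of the two numbers in a functional assay on the whole organism for inhibition, with Rattus norvegicus as the target, with a stated time of 3 h, at a dose of 1 mg/kg by the oral route (a higher number here means more inhibition at the dose given (going by the name of the read-out), a lower number less inhibition), with compound 1 as its nearest neighbour; the one step so far, a number 12 percentage points higher from compound 1 to compound 2 (beyond the scatter), lies beyond the scatter. Compound 3, `CCCCc1nc2cccc(C(=O)O)c2n1Cc1ccc(-c2ccccc2-c2noc(O)n2)cc1`, has not yet been measured. It differs from compound 2 by methyl in place of hydrogen on a saturated chain carbon, three bonds along the chain from an aromatic carbon. Within the data shown here, the only measured step that bears on this change is the one from compound 1 to compound 2, a modest rise from adding a methyl one bond closer to the aromatic carbon. Among the measured compounds shown here, compound 2 already gives the higher of the two numbers in this assay, and a fall beyond the scatter from that number would have to come from the new methyl alone, for which no measured step gives evidence. Compound 3 is therefore expected to stay about level, with a number 3 percentage points lower from compound 2 to compound 3 (within the scatter). The estimate for compound 3 is 97%, within 85% to 100%.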

Compound 3, a percentage reported as inhibition, in the whole organism at one dose (the size of the read-out at that dose, not a potency): 68%
Estimate against measurement, compound 3: 29 percentage points above; measured number below the stated range.
By their numbers in this assay, from the lowest: compound 3; then compound 1; then compound 2.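

In this assay, the added carbons do not all act alike: the methyl in place of hydrogen, three bonds along the chain from an aromatic carbon, gives a number 32 percentage points lower from compound 2 to compound 3 (beyond the scatter) and so reverses the rise seen one bond closer in. The butyl chain of compound 3 also stands under the ethyl chain of compound 1, with a number 20 percentage points lower from compound 1 to compound 3 (beyond the scatter) in this assay, so among these three compounds the propyl chain gives the highest number and the trend with chain length turns over instead of climbing steadily. No measurement given here explains this fall. On these data alone, whether a pentyl or longer chain would fall further remains open, as does whether a branched chain such as isopropyl would hold the number of compound 2. Also open, as far as these compounds go, is where a plain methyl at this place would stand against the ethyl chain of compound 1.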